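The source may hold more compounds than are shown below. What is called first, only, known or untested is meant among the compounds shown, and "the series" means these compounds.

Working notes on the series. Compound 2 `COc1ccc(-c2ccc3c(c2)C(=O)C(=O)N3)cc1` carries methoxy on an aromatic carbon. Among the compounds with values here, in a functional assay on K562 cells (Homo sapiens) for antiproliferative activity, read by MTT assay, with a stated time of 48 h (on this read-out higher numbers stand for weaker inhibition and lower numbers for stronger inhibition), compound 2 gives 6920 nM, the only number among the three values shown. Compound 1 `Cc1ccc(-c2ccc3c(c2)C(=O)C(=O)N3)cc1` reaches only a limit of the assay in this assay, namely > 10000 nM. Compound 3 `O=C1Nc2ccc(-c3ccc(C(F)(F)F)cc3)cc2C1=O` likewise reaches only a limit in this assay, namely > 10000 nM. The picture is thus (the limit of > 10000 nM in this assay, at which 2 of the 3 values shown sit). The measured steps all concern the group on that aromatic carbon: an at least 1.4-fold lower number from compound 1 to compound 2 (0.15 log units; that floor lies within the scatter), an at least 1.4-fold higher number from compound 2 to compound 3 (0.15 log units; that floor lies within the scatter), and a step that the two limits leave unreadable from compound 1 to compound 3. Compound 4 `COc1ccc(-c2ccc3c(c2)C(=O)C(=O)N3C)cc1` differs from compound 2 elsewhere: methyl in place of hydrogen on an amide-type nitrogen in a ring. Within the data shown here, none of the measured steps touches the amide-type nitrogen in a ring, so no measured step bears on this change, and the expectation rests on the value of compound 2 alone. Compound 4 is therefore expected to show a 1.2-fold higher number from compound 2 to compound 4 (0.06 log units; within the scatter), nothing beyond the scatter. The estimate for compound 4 in this assay is 8000 nM, between 2500 nM and 25000 nM, with a fair chance that only a limit is reported.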

Compound 4, half-maximal inhibitory concentration: 4980 nM
Estimate against measurement, compound 4: 1.6-fold (0.21 log units) above; measured number inside the range.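

In this assay, within the data shown here, methyl in place of hydrogen on the amide-type nitrogen in a ring gives a 1.4-fold lower number from compound 2 to compound 4 (0.14 log units; within the scatter), the first measured step at this position. The amide hydrogen is thus not needed for a readable value: compound 4, which lacks it, still gives a number, 4980 nM. Methoxy on the aromatic carbon is common to compound 2 and compound 4, the two compounds with numbers, whereas compound 1 and compound 3 each reach only a limit of the assay: the limit of > 10000 nM in this assay, at which 2 of the 4 values shown sit.

Open, as far as these compounds go, is whether a longer chain or a chain ending in an amine on the amide-type nitrogen would stay as close to compound 2 as methyl does. Also open, from the compounds shown here alone, is whether the methyl step holds with a group other than methoxy on the aromatic carbon, such as a carboxylic acid.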